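Notes on 3,5-dichlorobenzyl to 4-fluorobenzyl in the series

The source may report more compounds than this note shows. Statements on the series, on what has been measured and on what is new or still open speak of the compounds shown alone.

- compound 1 `CCc1nc2c(C)cc(-c3ccc(CN4CCC[C@H]4CO)cc3)cn2c1NC(=O)OCc1cc(Cl)cc(Cl)c1` | "nd" (no result reported) |
- compound 2 `CCc1nc2c(C)cc(-c3ccc(CN4CCN(C)CC4)cc3)cn2c1NC(=O)OCc1cc(Cl)cc(Cl)c1` | 5780 nM |

Compound 1 has no single number in a functional assay on MCF7 cells (Homo sapiens) for inhibition, read by MTT assay, with a stated time of 72 h (a lower number here means a stronger inhibitor, a higher number a weaker inhibitor), and its entry reads "nd" (no result reported) so its standing in the series is open and it offers no starting value. Among the measured compounds shown here, compound 2 gives 5780 nM as the only measured number available.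

Compound 3 `CCc1nc2c(C)cc(-c3ccc(CN4CCC[C@H]4CO)cc3)cn2c1NC(=O)OCc1ccc(F)cc1` departs from compound 1 at one place (4-fluorophenyl in place of 3,5-dichlorophenyl on a saturated chain carbon bound to an oxygen next to a carbonyl group). It carries 4-fluorophenyl in place of 3,5-dichlorophenyl on a saturated chain carbon bound to an oxygen next to a carbonyl group. For the measured compounds named here, no measured step covers this change, so no step beyond the scatter is expected in this assay and no direction is assigned. The estimate therefore leans on compound 2 at 5780 nM and carries a wide range. Compound 3 is expected at 6000 nM (estimated range 1500 nM to 25000 nM).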

Compound 3, half-maximal inhibitory concentration: > 20000 nM
Compound 3 gave a limit, no number; the forecaster's own chance of this, stated with the estimate: 15%; middle value at least 3.3-fold (0.52 log units) away from the limit.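

In this assay compound 3 gives > 20000 nM as a limit and not a number. Among the compounds shown here, compound 1 reads "nd" (no result reported) so no step between compound 1 and compound 3 can be read. Left open is how far 3,5-dichlorobenzyl to 4-fluorobenzyl moves the value in this assay within this series.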